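Swapping Thiophene for Furan on a Shared Core

The source may hold more compounds than are shown below. What is called first, only, known or untested is meant among the compounds shown, and "the series" means these compounds.

Compound 1 `Oc1cccc(-c2cc(-c3ccsc3)cc(-c3cccc(O)c3)n2)c1` — 1310 nM
Compound 2 `Oc1ccc(-c2cc(-c3ccsc3)cc(-c3cccc(O)c3)n2)cc1` — 2230 nM

In a functional assay on DU-145 cells (Homo sapiens) for cytotoxicity, read by CCK-8 assay (a higher number here means a weaker inhibitor, a lower number a stronger inhibitor), compound 1 and compound 2 sit close together: a 1.7-fold higher number from compound 1 to compound 2 (0.23 log units; within the scatter). Compound 3 `Oc1cccc(-c2cc(-c3ccco3)cc(-c3cccc(O)c3)n2)c1` differs from compound 1 by furan-2-yl in place of thiophen-3-yl on an aromatic carbon. Among the compounds with values here, no measured step touches this group; the only step known alters a hydroxyphenyl elsewhere on the core and stays within the scatter, so it offers no guide to direction. For compound 3 the step of a 1.1-fold higher number from compound 1 to compound 3 (0.03 log units; within the scatter) is therefore expected to stay within the scatter. Compound 3 is estimated at 1400 nM, within 500 nM to 4000 nM.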

Compound 3, half-maximal inhibitory concentration: 2150 nM
Compound 3: the middle estimate sits 1.5-fold (0.19 log units) below what was measured; measured number inside the range.
By their numbers in this assay, from the lowest: compounds 1, 3 and 2 (each within the scatter of the next).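

Within the data shown here, this is the first step to touch the group opposite the ring nitrogen: in this assay furan-2-yl in place of thiophen-3-yl gives a step (a 1.6-fold higher number from compound 1 to compound 3 (0.22 log units; within the scatter)) that stays within the scatter. At this place, then, oxygen in a furan-2-yl ring and sulfur in a thiophen-3-yl ring cannot be told apart by these numbers. No measurement offered here explains this result.

Both groups are five-membered aromatic rings, so the step says little about a very different group. As far as these compounds go, whether an amine, a carboxylic acid or a longer chain at this place would move the number beyond the scatter remains open.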